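Naphthalen-1-yl Urea Variant on a Shared Kinase Core

This account rests on a few compounds, and the source may have more. Where it says the series, first, only, none or still open, it means among the compounds named here.

Compound 1 `COc1cccc(NC(=O)Nc2ccc(Nc3ncnc4c3OCCN4)cc2)c1` reaches only the limit of an assay on isolated protein for inhibition of proto-oncogene tyrosine-protein kinase receptor Ret variant V804L (Homo sapiens), read by 33P incorporation, with stated times of 15 min and 40 min (a lower number here means a stronger inhibitor, a higher number a weaker inhibitor), > 10000 nM.
Compound 2 `Cc1cc(C)cc(NC(=O)Nc2ccc(Nc3ncnc4c3OCCN4)cc2)c1` gives 3770 nM in this assay.
Compound 3 `O=C(Nc1ccc(Nc2ncnc3c2OCCN3)cc1)Nc1cc(Cl)cc(Cl)c1` gives 4480 nM in this assay.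

Compound 3 holds the higher of the two measured numbers, yet its nearest neighbour lies within the scatter: a 1.2-fold higher number from compound 2 to compound 3 (0.07 log units; within the scatter). Compound 4 `O=C(Nc1ccc(Nc2ncnc3c2OCCN3)cc1)Nc1cccc2ccccc12` differs from compound 3 by naphthalen-1-yl in place of 3,5-dichlorophenyl on an amide-type nitrogen. The measured steps concern other groups: an at least 2.6-fold lower number from compound 1 to compound 2 (0.42 log units; beyond the scatter) and an at least 2.2-fold lower number from compound 1 to compound 3 (0.34 log units; beyond the scatter), both counted from a limit (the limit of > 10000 nM in this assay, at which 1 of the 3 values shown sits). None involves a naphthalen-1-yl group, and compounds 2 and 3 show that exchanging one pair of ring substituents for another leaves the number near its place. No step beyond the scatter is therefore expected; the step from compound 3 to compound 4 is estimated as a 1.1-fold higher number from compound 3 to compound 4 (0.05 log units; within the scatter). Compound 4 is expected at about 5000 nM, between 1500 nM and 15000 nM.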

Compound 4, half-maximal inhibitory concentration: > 10000 nM
Compound 4: a limit, no number (the forecaster's own chance of this, stated with the estimate: 30%); at least 2.0-fold (0.30 log units) between middle value and limit.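

Compound 4 stands at a limit of this assay, not at a number: the limit of > 10000 nM in this assay, at which 2 of the 4 values shown sit.

Unlike the exchange of one pair of ring substituents for another, naphthalen-1-yl on the amide-type nitrogen moves the read-out beyond the scatter, with an at least 2.2-fold higher number from compound 3 to compound 4 (0.34 log units; beyond the scatter) and an at least 2.6-fold higher number from compound 2 to compound 4 (0.42 log units; beyond the scatter). The step between compound 1 and compound 4 cannot be read, as both values are limits.

Going by these compounds, how far compound 4 lies past its limit remains open. So does whether naphthalen-2-yl, or a phenyl ring carrying a single chlorine or a trifluoromethyl group, would stay near compound 2 and compound 3.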